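Anilide methoxy for bromo on the nitro member

This account rests on a few compounds, and the source may have more. Where it says the series, first, only, none or still open, it means among the compounds named here.

Three compounds of the series carry a measurement in a functional assay on MCF7 cells (Homo sapiens) for cytotoxicity, read by MTT assay, with a stated time of 48 h; a lower number here means a stronger inhibitor, a higher number a weaker inhibitor. Compound 1 `COc1ccc(NC(=O)c2cn(-c3ccccc3)nc2-c2ccc(OC)cc2)cc1` gives 1770 nM, and compound 2 `COc1ccc(NC(=O)c2cn(-c3ccccc3)nc2-c2ccc(Cl)cc2)cc1` gives 1550 nM. Among the measured compounds shown here, the only single-site step among them, a 1.1-fold lower number from compound 1 to compound 2 (0.06 log units; within the scatter), is chloro in place of methoxy on an aromatic carbon and stays within the scatter. Compound 3 `O=C(Nc1ccc(Br)cc1)c1cn(-c2ccccc2)nc1-c1ccc([N+](=O)[O-])cc1` gives 5300 nM and stands highest of the three numbers, beyond the scatter from both compound 1 and compound 2; it differs from them in two places at once, so nothing ties its higher number to either the nitro group or the bromo alone.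

Compound 4 `COc1ccc(NC(=O)c2cn(-c3ccccc3)nc2-c2ccc([N+](=O)[O-])cc2)cc1` shares the nitro-bearing ring of compound 3 and takes (methoxy in place of bromo on an aromatic carbon). For the measured compounds named here, no measured step covers this exchange on the anilide ring; the one measured step concerns the other ring and was flat. Compound 1 and compound 2, both methoxy anilides, give lower numbers than compound 3, which leaves the direction of the step open but allows a moderate fall. The step from compound 3 to compound 4 in this assay is therefore expected to be a 1.8-fold lower number from compound 3 to compound 4 (0.25 log units; within the scatter), with wide uncertainty. For compound 4 in this assay a value of 3000 nM is estimated, in the range 1100 nM to 8500 nM.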

Compound 4, half-maximal inhibitory concentration: 1210 nM
Compound 4: middle estimate off by 2.5-fold (0.39 log units), on the high side; measured number inside the range.
By their numbers in this assay, from the lowest: compounds 4, 2 and 1 (each within the scatter of the next); then compound 3.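

Methoxy in place of bromo on this aromatic carbon gives the first step in the series beyond the scatter (a 4.4-fold lower number from compound 3 to compound 4 (0.64 log units; beyond the scatter)), and with the nitro group held constant, the higher number of compound 3 follows the bromo and not the nitro group. With the 4-methoxyphenyl amide held constant, the other substituted site stays flat: nitro in place of chloro (a 1.3-fold lower number from compound 2 to compound 4 (0.11 log units; within the scatter)) and nitro in place of methoxy (a 1.5-fold lower number from compound 1 to compound 4 (0.17 log units; within the scatter)) both lie within the scatter, as did the earlier chloro for methoxy step, so in this assay this site separates none of compounds 1, 2 and 4. No evidence on hand accounts for the size of the bromo to methoxy step.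

Going by these compounds, the exchange is read on the nitro member alone, so whether a bromo anilide would also give a higher number with chloro or methoxy on the other ring remains open. Equally open, on these data alone, is how this position responds to groups such as an amine, a carboxylic acid or a longer alkoxy chain, since only bromo and methoxy are compared here.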